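The source may hold more compounds than are shown below. What is called first, only, known or untested is meant among the compounds shown, and "the series" means these compounds.

Measured so far:
Compound 1, `CCNC(=O)Nc1cc(=O)oc2cc(OCc3cccc(Cl)c3)ccc12`; in an assay on brain (strain Sprague-Dawley) for inhibition of Amine oxidase [flavin-containing] B (Rattus norvegicus), read by spectrophotometry (on this read-out higher numbers stand for weaker inhibition and lower numbers for stronger inhibition), compound 1 gives 31600 nM.
Compound 2, `O=C(O)COc1cc(=O)oc2cc(OCc3cccc(Cl)c3)ccc12`; in this assay compound 2 gives 31600 nM.

Compound 2 stands level with compound 1 at the digits shown, and the single measured step, no change at the digits printed from compound 1 to compound 2 (within the scatter), lies within the scatter. Compound 3, `O=c1cc(CCCl)c2ccc(OCc3cccc(Cl)c3)cc2o1`, is not yet measured. It differs from compound 2 by 2-chloroethyl in place of carboxymethoxy on an aromatic carbon. For the measured compounds named here, only the step from compound 1 to compound 2 bears on this change, and it bears only loosely: it swapped two different groups at the same site and was flat. Going by the values given here, no measured step replaces a carboxymethoxy group with a chloroethyl chain, so neither size nor direction is fixed by the data. Compound 3 is therefore expected to give about 20000 nM, within a broad range from 3000 nM to 100000 nM. The step this estimate means, a 1.6-fold lower number from compound 2 to compound 3 (0.20 log units; within the scatter), is expected to stay near the scatter.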

Compound 3, half-maximal inhibitory concentration: 12.9 nM
The estimate for compound 3 lay 1600-fold (3.19 log units) above the measured number, and the stated range ends above it.
By their numbers in this assay, from the lowest: compound 3; then compounds 1 and 2 (each within the scatter of the next).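

In this assay this position, opposite the ring oxygen, turns out to be highly sensitive to the group it carries: 2-chloroethyl in place of carboxymethoxy gives a 2400-fold lower number from compound 2 to compound 3 (3.39 log units; beyond the scatter) and 2-chloroethyl in place of (ethylcarbamoyl)amino gives a 2400-fold lower number from compound 1 to compound 3 (3.39 log units; beyond the scatter) on the same shared core. For the compounds shown here, the two earlier compounds, level with each other, gave no sign that a group at this site could move the number so far. No accompanying measurement bears on why the 2-chloroethyl group has this effect.

The compounds shown leave open whether the gain requires the chlorine or only the two-carbon chain, a question that an ethyl or 2-hydroxyethyl group would address. They also leave open how a longer chain such as 3-chloropropyl, or an amine at the end of the chain, would read in this assay.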